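This account rests on a few compounds, and the source may have more. Where it says the series, first, only, none or still open, it means among the compounds named here.

Measured so far:
compound 1, `CC[C@@H](Nc1c(C#N)c(-c2ccc(-c3ncccc3C)cc2)nc2cnccc12)C(N)=O`, 2
compound 2, `CCOc1ccccc1-c1ccc(-c2nc3cnccc3c(N[C@H](CC)C(=O)NS(=O)(=O)C3CC3)c2C#N)cc1`, 2.3
compound 3, `CN(CC(N)=O)c1c(C#N)c(-c2ccc(Br)cc2)nc2cnccc12`, 2.1

All three compounds share one core and were read in a physicochemical assay for lipophilicity, read by HPLC, at pH 7.5; a higher number here means a more lipophilic compound, a lower number a more polar compound. On this measure compound 1, compound 2 and compound 3 sit close together: every gap between any two of them lies within the usual scatter of repeated measurements, so none of the three can be called more or less lipophilic than another on this evidence. Compound 1 is simply one of three close numbers.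

The compound not yet measured is compound 4, `CC[C@@H](Nc1c(C#N)c(-c2ccc(-c3ccc(Cl)cc3)cc2)nc2cnccc12)C(N)=O`. It differs from compound 1 in one place only:

4-chlorophenyl in place of 3-methylpyridin-2-yl on an aromatic carbon

The group that leaves is a six-membered aromatic ring with one hetero atom and one hydrogen-bond acceptor; the group that enters is a six-membered aromatic ring of carbon only, with no hydrogen-bond acceptor, sitting para to a large group.

Among the measured compounds shown here, no two measured compounds differ in just one place, so no measured step shows what such a swap does here. Even so, the step of a number 1.00 log units higher from compound 1 to compound 4 (beyond the scatter) is expected to go upward, beyond the scatter. Compound 4 is therefore estimated to read about 3, most likely between 2.4 and 3.6.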

Compound 4, distribution coefficient: 3.1
Compound 4: middle estimate off by 0.10 log units, on the low side, within the range that was stated.
By their numbers in this assay, from the lowest: compounds 1, 3 and 2 (each within the scatter of the next); then compound 4.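

In this assay, among the compounds shown here, this position on the aromatic carbon, para to a large group, proves able to move the reading: placing 4-chlorophenyl where 3-methylpyridin-2-yl stood gives a number 1.10 log units higher from compound 1 to compound 4 (beyond the scatter), whereas the earlier compounds sat too close to separate and included no pair differing in one place. The heavy-atom count does not change in this swap, as both groups have 7 heavy atoms and one six-membered aromatic ring, so a step of this size can arise here without any change in that count; the differences lie in what the ring carries, with chlorine entering, the ring nitrogen and its hydrogen-bond acceptor leaving, and the methyl leaving too. For the compounds shown here, no independent evidence here explains the step, and the single swap changes all these features together.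

As far as these compounds go, the share of the step belonging to the chlorine, the ring nitrogen or the methyl remains open, and a plain phenyl, a 3-methylphenyl or a pyridin-2-yl without the methyl at this place would help to separate them. Also open, from the compounds shown here alone, is whether the same swap gives a similar step when the amide side chain of compound 1 is replaced by another group, such as a carboxylic acid.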